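Methyl to 1-Hydroxyethyl on the Amide-Bearing Carbon

The source may hold more compounds than are shown below. What is called first, only, known or untested is meant among the compounds shown, and "the series" means these compounds.

Three measured compounds:
Compound 1 `C[C@H](NC(=O)CN(c1ncnc2c1ncn2C1CCCCO1)C1CC1)C(=O)OCc1ccccc1` gives 55.9% in a functional assay on the whole organism (Tail, strain ICR) with Mus musculus as the target, in the tail flick test, with a stated time of 30 min, at a dose of 25 umol/kg by the oral route; on this read-out lower numbers stand for a weaker effect and higher numbers for a stronger effect at the one dose given.
Compound 2 `CC(C)[C@H](NC(=O)CN(c1nc(Cl)nc2[nH]cnc12)C1CC1)C(=O)OCc1ccccc1` gives 33.4% in this assay.
Compound 3 `NC(=O)C[C@H](NC(=O)CN(c1nc(Cl)nc2[nH]cnc12)C1CC1)C(=O)OCc1ccccc1` gives 24.4% in this assay.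

Compound 1 stands highest of the three numbers in this assay, and both of its gaps lie beyond the scatter: compound 2 sits closest, compound 3 furthest. The unmeasured compound 4 `C[C@@H](O)[C@H](NC(=O)CN(c1ncnc2c1ncn2C1CCCCO1)C1CC1)C(=O)OCc1ccccc1` shares the core of compound 1 and differs from it in one place: 1-hydroxyethyl in place of methyl on a saturated chain carbon bound to an amide-type nitrogen and a carbonyl carbon.

Among the compounds with values here, only one measured step bears on this change, and only loosely. It lies on a different core, between compound 2 and compound 3, where the group on the same saturated chain carbon was exchanged, and it gave a number 9 percentage points lower from compound 2 to compound 3 (within the scatter). Within the data shown here, that exchange altered the group on the carbon bound to the amide-type nitrogen and the carbonyl carbon without moving the read-out beyond the scatter, which is the closest precedent for what 1-hydroxyethyl in place of methyl might do. Among the measured compounds shown here, no step from methyl to a hydroxyl-bearing group is available in this set.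

The account therefore expects compound 4 to remain near compound 1, with the step of a number 7.9 percentage points lower from compound 1 to compound 4 (within the scatter) staying within or only just beyond the scatter, and a slight lowering judged more likely than a rise because a number 9 percentage points lower from compound 2 to compound 3 (within the scatter) pointed downward. Compound 4 is estimated at 48%, with a range from 25% to 70%.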

Compound 4, a percentage reported as activity, at one dose (the size of the read-out at that dose, not a potency): 23.6%
Compound 4: middle estimate off by 24.4 percentage points, on the high side; the measured number lies below the stated range.
By their numbers in this assay, from the lowest: compounds 4, 3 and 2 (each within the scatter of the next); then compound 1.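

In this assay, putting 1-hydroxyethyl in place of methyl on a saturated chain carbon bound to an amide-type nitrogen and a carbonyl carbon gave a number 32.3 percentage points lower from compound 1 to compound 4 (beyond the scatter), which shows that on the core of compound 1 the read-out depends strongly on the group at this place. The only earlier step at this carbon, a number 9 percentage points lower from compound 2 to compound 3 (within the scatter), involved a different exchange on a different core, and it had not shown that a change here could move the read-out so far. No measurement given here accounts for this drop.

As far as these compounds go, it remains open whether the loss follows the added carbons or the hydroxyl, a question that an ethyl group and a hydroxymethyl group at this place on the core of compound 1 could help to separate. Also open, from the compounds shown here alone, are how an amine or a carboxylic acid would read at the same carbon, and whether 1-hydroxyethyl with the opposite configuration at its defined stereocentre would give the same number.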